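A few compounds are considered here, and "the series" means these few. Any claim that something is new, unique, unknown or untested is made for them only; others in the source may bear on it.

Of the compounds shown here, three sharing one core have been measured in an assay on HeLa cells for inhibition of Kinesin-like protein KIF15 (Homo sapiens), read by microscopy, with stated times of 2 s and 20 s, tested at 750 nM; on this read-out lower numbers stand for less inhibition and higher numbers for more inhibition at the one concentration tested (going by the name of the read-out). Compound 1 `O=C1Nc2ccc(C(=O)N3CCCC3)cc2/C1=C/c1cc(Cl)c(O)c(Cl)c1` gives -10%, compound 2 `O=C1Nc2ccc(-c3ccco3)cc2/C1=C/c1cc(Cl)c(O)c(Cl)c1` gives 33%, and compound 3 `O=C1Nc2ccc(-c3cccc(F)c3)cc2/C1=C/c1cc(Cl)c(O)c(Cl)c1` gives -5.8%. Compound 3 therefore holds the second highest of the three numbers: its nearest neighbour is compound 1, with a number 4.2 percentage points higher from compound 1 to compound 3 (within the scatter), and its furthest is compound 2, with a number 38.8 percentage points lower from compound 2 to compound 3 (beyond the scatter). Compound 4 `O=C1Nc2ccc(I)cc2/C1=C/c1cc(Cl)c(O)c(Cl)c1` differs from compound 3 in one place: iodo in place of 3-fluorophenyl on an aromatic carbon. Within the data shown here, no measured step introduces an iodo group, so the earlier changes at this position, including a number 43 percentage points higher from compound 1 to compound 2 (beyond the scatter), offer only a loose guide. A small step is expected, a number 7.8 percentage points higher from compound 3 to compound 4 (within the scatter). Compound 4 is estimated at 2%, between -22% and 28%.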

Compound 4, a percentage reported as inhibition, at one concentration (the size of the read-out at that concentration, not a potency): 15%
Estimate against measurement, compound 4: 13 percentage points below; measured number inside the range.
By their numbers in this assay, from the lowest: compounds 1 and 3 (each within the scatter of the next); then compound 4; then compound 2.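

A lone iodo atom, with no ring, gives more inhibition at this position than 3-fluorophenyl (a number 20.8 percentage points higher from compound 3 to compound 4 (beyond the scatter)) and more than (pyrrolidin-1-yl)carbonyl (a number 25 percentage points higher from compound 1 to compound 4 (beyond the scatter)), but less than furan-2-yl (a number 18 percentage points lower from compound 2 to compound 4 (beyond the scatter)). A ring at this aromatic carbon is therefore not needed for inhibition, and the two aromatic ring groups land on opposite sides of iodo, so having a ring there does not by itself set the number. Nothing available explains this order. Where chloro, bromo or an amine would fall at this position remains open. So does whether the order holds at other concentrations.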